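The source may hold more compounds than are shown below. What is called first, only, known or untested is meant among the compounds shown, and "the series" means these compounds.

Measured so far in a functional assay on the whole organism (strain Kunming) with Mus musculus as the target, in the formalin test, with a stated time of 0.5 h (a lower number here means that less compound is needed, a higher number that more compound is needed for the effect), with these results:
- compound 1 `COc1cc(OC)c(OC)cc1/C=C/COC(=O)/C=C/c1ccccc1C(F)(F)F` gives 291 umol/kg
- compound 2 `COc1cc(OC)c(OC)cc1/C=C/COC(=O)/C=C/c1ccc(F)cc1` gives 117 umol/kg
- compound 3 `COc1ccc(/C=C/C(=O)OC/C=C/c2cc(OC)c(OC)cc2OC)cc1` gives 317 umol/kg

Compound 3 (317 umol/kg) sits at the upper end of this small set, level with compound 1, as a 1.1-fold higher number from compound 1 to compound 3 (0.04 log units; within the scatter) shows.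

Compound 4 `COc1cc(OC)c(OC)cc1/C=C/COC(=O)/C=C/c1ccc(Cl)cc1` carries chloro in place of methoxy on an aromatic carbon para to a large group (chloro in place of methoxy on an aromatic carbon), so 4-methoxyphenyl becomes 4-chlorophenyl.

Going by the values given here, two measured steps bear on this change. The closest exchanges fluoro and methoxy at the same place and gives a 2.7-fold higher number from compound 2 to compound 3 (0.43 log units; beyond the scatter) as a modest change. The other is a 2.5-fold lower number from compound 1 to compound 2 (0.40 log units; beyond the scatter) and ends at the same 4-fluorophenyl compound, also modest. Among the compounds with values here, no chloro compound has been measured. Within the data shown here, with compound 2 (117 umol/kg) as the only guide for a halogen at that place, a lower number than compound 3 is expected in this assay, of a size near the edge of the scatter. The expected change is a 1.9-fold lower number from compound 3 to compound 4 (0.27 log units; within the scatter) in this estimate. Compound 4 is estimated at 170 umol/kg with an expected range of 75 umol/kg to 380 umol/kg for now.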

Compound 4, dose for half-maximal effect: 278 umol/kg
Compound 4: the middle estimate sits 1.6-fold (0.21 log units) below what was measured; the measured number falls inside the stated range.
By their numbers in this assay, from the lowest: compound 2; then compounds 4, 1 and 3 (each within the scatter of the next).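

In this assay, chloro in place of methoxy on an aromatic carbon para to a large group gives a 1.1-fold lower number from compound 3 to compound 4 (0.06 log units; within the scatter) and so does not separate 4-chlorophenyl from 4-methoxyphenyl, while a 1.0-fold lower number from compound 1 to compound 4 (0.02 log units; within the scatter) leaves it equally level with 2-(trifluoromethyl)phenyl. The lower number of the 4-fluorophenyl compound therefore does not extend to the other halogen tested here: a 2.4-fold higher number from compound 2 to compound 4 (0.38 log units; beyond the scatter) and, of the four compounds, only compound 2 has steps to all the others that lie beyond the scatter. Going by these compounds alone, the series so far offers no independent data that would account for this separation of fluoro from chloro.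

On these data alone, it remains open whether fluoro is a lone exception at this place or one of several groups giving a lower number, which bromo, hydrogen, an amine or a carboxylic acid on the same aromatic carbon could help to settle. Also open, as far as these compounds go, is whether the gap between fluoro and chloro would persist with an amide in place of the ester or with a different substitution pattern on the trimethoxyphenyl part of the shared core.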